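The compounds below may be only part of what the source reports. "The series", "measured", "known", "first", "only" and "open" are said of these compounds alone.

Compound 1 `NCCCCN(C[C@@H]1Cc2ncccc2CN1)[C@H]1CCCc2cccnc21`: 75%
Compound 2 `NCCCCN(C[C@H]1Cc2nccnc2CN1)[C@H]1CCCc2cccnc21`: 77%
Compound 3 `NC(=O)NC/C=C\CN(C[C@H]1Cc2ncccc2CN1)[C@H]1CCCc2cccnc21`: 10%

These values come from an ADME assay on microsomes from liver (Mus musculus) for metabolic stability, using NADPH, with a stated time of 10 min; on this read-out higher numbers stand for a more stable compound and lower numbers for a less stable compound. Compound 3 has the lowest number of the three, and its gap to each of the other two lies beyond the usual scatter. Compound 4 `c1cnc2c(c1)CN[C@@H](CN(CCCCNC1COC1)[C@H]1CCCc3cccnc31)C2` has not yet been measured. It differs from compound 3 on a saturated chain carbon bound to an amine nitrogen: a group of 8 heavy atoms (6 carbon, 1 nitrogen, 1 oxygen; one four-membered non-aromatic ring with 1 hetero atom) in place of a group of 7 heavy atoms (4 carbon, 2 nitrogen, 1 oxygen; no ring), on a saturated chain carbon bound to an amine nitrogen. Among the compounds with values here, no measured pair shows this change directly, so the expectation is uncertain. Like compound 1 and compound 2, compound 4 has a saturated chain, whereas compound 3 does not. A clear rise beyond the scatter is therefore expected, with an estimated a number 45 percentage points higher from compound 3 to compound 4 (beyond the scatter). In this assay, the estimated value for compound 4 is 55%, with an expected range of 25% to 85%.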

Compound 4, percent of the compound remaining: 41%
Compound 4: the middle estimate sits 14 percentage points above what was measured; the range from low to high includes it.
By their numbers in this assay, from the lowest: compound 3; then compound 4; then compounds 1 and 2 (each within the scatter of the next).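

In this assay, putting a group with one four-membered non-aromatic ring with 1 hetero atom in place of a group with no ring and 2 double bonds outside aromatic rings gives a number 31 percentage points higher from compound 3 to compound 4 (beyond the scatter). What sits on a saturated chain carbon bound to an amine nitrogen can therefore move this read-out by more than repeat measurements vary. Nothing measured here accounts for the rise. The whole group changes in this one step, so the part that matters cannot be singled out. From the compounds shown here alone, how a carboxylic acid or a six-membered ring containing oxygen would behave at this place remains open.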